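The source may hold more compounds than are shown below. What is called first, only, known or untested is meant among the compounds shown, and "the series" means these compounds.

Compound 2 `C[C@H](NC(=O)c1cccc2c1N(Cc1ccc(F)cc1)CC2)c1ccc(C(=O)O)cc1` stands at the weaker end of the two measured compounds: in a functional assay on HEK293 cells for antagonist activity at prostaglandin E2 receptor EP4 subtype (Homo sapiens), read by scintillation proximity assay and cAMP accumulation (a lower number here means a stronger inhibitor, a higher number a weaker inhibitor), compound 2 gives 6.2 nM, whereas compound 1 `C[C@H](NC(=O)c1cccc2c1N(Cc1ccc(Cl)c(Cl)c1)CC2)c1ccc(C(=O)O)cc1` gives 1.1 nM. Among the compounds with values here, the single measured step between them, a 5.6-fold higher number from compound 1 to compound 2 (0.75 log units; beyond the scatter), shows that replacing the 3,4-dichlorophenyl of compound 1 with 4-fluorophenyl made the inhibitor noticeably weaker.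

Compound 3 `C[C@H](NC(=O)c1cccc2c1N(Cc1ccc(Cl)cc1Br)CC2)c1ccc(C(=O)O)cc1` has not yet been tested. It differs from compound 2 by 2-bromo-4-chlorophenyl in place of 4-fluorophenyl on a saturated chain carbon bound to a nitrogen on an aromatic ring in a ring. This brings a ring bearing chlorine and bromine in place of the single fluorine, which resembles the direction of compound 1 without being the same pattern. Within the data shown here, only one measured step bears on the change, and it points one way: because a 5.6-fold higher number from compound 1 to compound 2 (0.75 log units; beyond the scatter) lies beyond the scatter, undoing that kind of exchange is expected to lower the number rather than raise it. The step from compound 2 to compound 3 is therefore estimated at about a 3.1-fold lower number from compound 2 to compound 3 (0.49 log units; beyond the scatter), somewhat short of the full span seen with compound 1, since the ring pattern is not identical. Compound 3 is expected to give about 2 nM in this assay, most likely between 0.7 nM and 6 nM.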

Compound 3, half-maximal inhibitory concentration: 8.3 nM
Compound 3: the middle estimate sits 4.2-fold (0.62 log units) below what was measured; measured number outside the range, above it.
By their numbers in this assay, from the lowest: compound 1; then compounds 2 and 3 (each within the scatter of the next).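

The step of a 1.3-fold higher number from compound 2 to compound 3 (0.13 log units; within the scatter) lies within the scatter, so the 2-bromo-4-chlorophenyl ring and the 4-fluorophenyl ring cannot be told apart at this position, and having chlorine and bromine on the ring does not by itself bring the stronger inhibition seen with compound 1. The step of a 7.5-fold higher number from compound 1 to compound 3 (0.88 log units; beyond the scatter) lies beyond the scatter, and here only the ring on the saturated chain carbon differs, so in these three compounds the result depends on which halogens the ring carries and how they are arranged, not simply on whether chlorine is present. No measurement given here explains why these rings differ in this way.

The compounds shown leave open whether the advantage of the 3,4-dichlorophenyl ring rests on both of its chlorines together or whether a ring such as 4-chlorophenyl would match it. They also leave open whether the bromine of compound 3 matters, and whether a ring carrying no halogen at all, such as one with a methoxy or a nitrile group, would behave like any of these three.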